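Saturated branched chain replaces the alkene on the aromatic nitrogen

This account rests on a few compounds, and the source may have more. Where it says the series, first, only, none or still open, it means among the compounds named here.

Three measured compounds share one core and differ only in the group on the aromatic nitrogen. In an assay on Prostate gland for inhibition of steroid 5-alpha-reductase (Rattus norvegicus) (a lower number here means a stronger inhibitor, a higher number a weaker inhibitor), compound 1 `CCCCCn1ccc2cc(/C(C)=C/C(=O)Nc3ccccc3OCCCC(=O)O)ccc21` gives 23 nM, compound 2 `CCCCCCn1ccc2cc(/C(C)=C/C(=O)Nc3ccccc3OCCCC(=O)O)ccc21` gives 77 nM, and compound 3 `CC(C)=CCn1ccc2cc(/C(C)=C/C(=O)Nc3ccccc3OCCCC(=O)O)ccc21` gives 120 nM. Compound 3 stands highest of the three numbers; its nearest neighbour is compound 2, with a 1.6-fold higher number from compound 2 to compound 3 (0.19 log units; within the scatter), and its furthest is compound 1, with a 5.2-fold higher number from compound 1 to compound 3 (0.72 log units; beyond the scatter).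

Compound 4 `CCCC(C)n1ccc2cc(/C(C)=C/C(=O)Nc3ccccc3OCCCC(=O)O)ccc21` is not yet measured. The change from compound 3 is 1-methylbutyl in place of 3-methylbut-2-en-1-yl on an aromatic nitrogen. The entering group is a saturated chain with the same heavy-atom count as the leaving group, so the step sits between the two kinds of chain already seen. For the measured compounds named here, two measured steps bear on it: a 5.2-fold higher number from compound 1 to compound 3 (0.72 log units; beyond the scatter), where the saturated chain was exchanged for the unsaturated one, and a 3.3-fold higher number from compound 1 to compound 2 (0.52 log units; beyond the scatter), where a saturated chain grew by one methyl. The third, a 1.6-fold higher number from compound 2 to compound 3 (0.19 log units; within the scatter), is within the scatter and adds little. Returning to a saturated five-carbon chain is therefore expected to give a modestly lower number in this assay than compound 3, though branching is untested here. Compound 4 is estimated at 45 nM, range 15 nM to 130 nM, a step of a 2.7-fold lower number from compound 3 to compound 4 (0.43 log units; beyond the scatter).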

Compound 4, half-maximal inhibitory concentration: 7.8 nM
Compound 4: the middle estimate sits 5.8-fold (0.76 log units) above what was measured, outside the stated range (below it).
By their numbers in this assay, from the lowest: compound 4; then compound 1; then compounds 2 and 3 (each within the scatter of the next).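

At the aromatic nitrogen, two groups with the same heavy-atom count end up far apart in this assay (a 15-fold lower number from compound 3 to compound 4 (1.19 log units; beyond the scatter)) when 1-methylbutyl enters in place of 3-methylbut-2-en-1-yl, so heavy-atom count alone does not set the number at this position. The saturated straight chains are also surpassed: 1-methylbutyl gives a lower number than pentyl (a 2.9-fold lower number from compound 1 to compound 4 (0.47 log units; beyond the scatter)) and than hexyl (a 9.9-fold lower number from compound 2 to compound 4 (0.99 log units; beyond the scatter)), which places compound 4 as the strongest inhibitor of the four, with all its steps beyond the scatter, and shows that a saturated chain on this nitrogen need not be straight to give a low number. Nothing available here bears on why the 1-methylbutyl group gives the lowest number.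

Still open, on these data alone, is whether the low number is specific to 1-methylbutyl or extends to related groups such as 1-methylpropyl, 1-ethylpropyl, 1-methylpentyl or a cyclopentyl ring on the same nitrogen. Also open, as far as these compounds go, is how the two mirror-image forms of the 1-methylbutyl group compare, since compound 4 is drawn without a defined arrangement at the branching carbon.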